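The compounds below may be only part of what the source reports. "The series", "measured", "known", "first", "only" and "open" are said of these compounds alone.

Measured so far in a functional assay on HEK293 cells for antagonist activity at transient receptor potential cation channel subfamily V member 1 (Homo sapiens), read by calcium flux; on this read-out lower numbers stand for stronger inhibition and higher numbers for weaker inhibition:
compound 1 `FC(F)(F)c1ccc(Nc2ncnc3sc(Nc4c(Cl)cccc4Cl)nc23)cc1`: 12 nM
compound 2 `CS(=O)(=O)c1ccc(Nc2ncnc3sc(Nc4c(Cl)cccc4Cl)nc23)cc1`: 5 nM
compound 3 `FC(F)(F)c1ccc(Nc2ncnc3sc(Nc4c(Cl)cccc4Cl)nc23)cc1Cl`: 21 nM

Compound 1 gives the second highest of the three numbers. Compound 3 sits nearest, a 1.8-fold higher number from compound 1 to compound 3 (0.24 log units; within the scatter); compound 2 sits furthest, a 2.4-fold lower number from compound 1 to compound 2 (0.38 log units; beyond the scatter). Both of these steps alter the substituent pattern on the (4-(trifluoromethyl)phenyl)amino side of the shared core; neither touches the core itself.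

Compound 4 `CC(C)Nc1nc(Nc2ccc(C(F)(F)F)cc2)c2nc(Nc3c(Cl)cccc3Cl)sc2n1` is not yet measured. Relative to compound 1 it carries isopropylamino in place of hydrogen on an aromatic carbon. For the measured compounds named here, no measured step changes this position of the shared core, so nothing so far bears directly on the move. Going by the values given here, the two known steps show only that changes on the aryl ring shift the number in this assay by a modest amount at most, in either direction. Without a precedent for substitution on the core, no direction can be argued from the data, and the scatter of the read-out has to be allowed for. The working expectation is that compound 4 stays close to compound 1, a 1.3-fold higher number from compound 1 to compound 4 (0.10 log units; within the scatter), with a wide range on either side. Compound 4 is therefore estimated at 15 nM in this assay, between 5 nM and 50 nM.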

Compound 4, half-maximal inhibitory concentration: 13 nM
Estimate against measurement, compound 4: 1.2-fold (0.06 log units) above; the measured number falls inside the stated range.
By their numbers in this assay, from the lowest: compound 2; then compounds 1, 4 and 3 (each within the scatter of the next).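

In this assay, for the compounds shown here, compound 4 gives the first reading on a change to the shared core itself, as opposed to the aryl ring: on the aromatic carbon between two ring nitrogen atoms, isopropylamino in place of hydrogen gives a 1.1-fold higher number from compound 1 to compound 4 (0.03 log units; within the scatter). A hydrogen can therefore give way at this position to a branched group of 4 heavy atoms, with its hydrogen-bond donor and acceptor, without a difference that this read-out can separate from the scatter, so the position is open to substitution at least for this one group. No measurement shown here accounts for this flat result or says what role, if any, the isopropylamino group plays.

A single substituent leaves open whether the flat result extends to other groups at this position, such as a plain amino group, a morpholine, a carboxylic acid or a longer alkylamino chain. Going by these compounds, it is also open whether isopropylamino at this position would leave the number unchanged on the methylsulfonyl aryl ring of compound 2 , which gives 5 nM without it.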